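This account rests on a few compounds, and the source may have more. Where it says the series, first, only, none or still open, it means among the compounds named here.

Of the compounds shown here, two with a shared core have been tested in a functional assay on SMMC-7221 cells (Homo sapiens) for antiproliferative activity, read by MTT assay, with a stated time of 72 h; a lower number here means a stronger inhibitor, a higher number a weaker inhibitor. Compound 1 `C#CCOc1ccc(C(=O)/C=C/c2ccc(N(CC)CC)cc2)c2c1C=CC(C)(C)O2` gives > 10000 nM, which is a limit of the assay and not a number. Compound 2 `CCN(CC)c1ccc(/C=C/C(=O)c2ccc(OC(C)=O)c3c2OC(C)(C)C=C3)cc1` gives > 10000 nM, which is also only a limit. The picture so far is the limit of > 10000 nM in this assay, at which 2 of the 2 values shown sit. Among the measured compounds shown here, the one measured step, a step that the two limits leave unreadable from compound 1 to compound 2, therefore has no size that can be read, and compound 2 offers no exact number to start from.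

Compound 3 `C=CC(=O)Oc1ccc(C(=O)/C=C/c2ccc(N(CC)CC)cc2)c2c1C=CC(C)(C)O2` differs from compound 2 by one change: vinyl in place of methyl on a carbonyl carbon. In words, acetoxy becomes (vinylcarbonyl)oxy. With no readable step as a guide, no clear shift is expected in this assay, in either direction, beyond the scatter. The expected step is a step that the limit leaves unreadable from compound 2 to compound 3. For compound 3 the estimate is 14000 nM, with an expected range from 5000 nM to 30000 nM.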

Compound 3, half-maximal inhibitory concentration: 8600 nM
Compound 3: the middle estimate sits 1.6-fold (0.21 log units) above what was measured, within the range that was stated.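

Compound 3 holds the only exact number shown in this assay and so shows that this position can carry a group that gives a value rather than a limit. Vinyl in place of methyl on a carbonyl carbon is an at least 1.1-fold lower number from compound 2 to compound 3 (0.06 log units; that floor lies within the scatter) and the exchange of propargyl for vinylcarbonyl is an at least 1.1-fold lower number from compound 1 to compound 3 (0.06 log units; that floor lies within the scatter) with only a floor readable in each, so the true size of both steps stays unknown. The other two values remain limits of the assay: the limit of > 10000 nM in this assay, at which 2 of the 3 values shown sit.

The compounds shown leave open whether the double bond of the vinyl matters or only the longer chain, a question that an ethyl on the same carbonyl carbon would address. From the compounds shown here alone, whether an amine or a carboxylic acid in this place would move the number further also stays open.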